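Ring substituent on the ether-linked aryl acid series

The source may hold more compounds than are shown below. What is called first, only, known or untested is meant among the compounds shown, and "the series" means these compounds.

Measured compounds:
compound 1 `COC(=O)c1ccc(OCCCCOc2ccc(C(=O)CC(C)C)c(O)c2C)cc1`, 16.4%
compound 2 `Cc1ccc(C(=O)O)cc1OCCCCOc1ccc(C(=O)CC(C)C)c(O)c1C`, 76.9%
compound 3 `Cc1ccc(C(=O)O)cc1OCCCCOc1ccc(C(=O)CC2CCCC2)c(O)c1C`, 67.5%

In an assay on HEK293 cells for positive allosteric modulation of metabotropic glutamate receptor 2 (Rattus norvegicus), read by thallium flux, with a stated time of 2.5 min (a lower number here means a smaller maximal response, a higher number a larger maximal response), compound 2 gives the highest of the three numbers; compound 3 lies a number 9.4 percentage points lower from compound 2 to compound 3 (within the scatter), and compound 1 is furthest, a number 60.5 percentage points higher from compound 1 to compound 2 (beyond the scatter). Compound 4 `Cc1c(OCCCCOc2ccc(C(=O)O)c(Cl)c2)ccc(C(=O)CC(C)C)c1O` differs from compound 2 as follows: 4-carboxy-3-chlorophenyl in place of 5-carboxy-2-methylphenyl on an oxygen on a saturated carbon. Within the data shown here, only the step of a number 60.5 percentage points higher from compound 1 to compound 2 (beyond the scatter) touches this aryl group, and it changes both the carboxylic acid versus ester and the ring pattern at once, so it does not separate the two. Compound 4 keeps the free acid of compound 2. A step for compound 4 of a number 16.9 percentage points lower from compound 2 to compound 4 (beyond the scatter) is expected, within the scatter or slightly downward. Compound 4 is estimated at 60%, between 30% and 85%.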

Compound 4, largest response reached (reported as percent of maximum), in percent of the reference or control that the assay uses: 80.5%
For compound 4 the middle estimate is 20.5 percentage points below the measured one; low and high end bracket the measured number.
By their numbers in this assay, from the lowest: compound 1; then compounds 3, 2 and 4 (each within the scatter of the next, the first and the last beyond it).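

In this assay, the aryl group on the oxygen takes 4-carboxy-3-chlorophenyl as readily as 5-carboxy-2-methylphenyl: a number 3.6 percentage points higher from compound 2 to compound 4 (within the scatter), so these two ring patterns carrying the free acid read alike. The step of a number 64.1 percentage points higher from compound 1 to compound 4 (beyond the scatter) repeats the large rise seen with compound 2, again with ester and ring pattern changed together. No evidence is available that bears on this result. Still open, on these data alone, is how a methyl ester behaves on either of these two rings, and whether a tetrazole or a primary amide can replace the carboxylic acid.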